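Working notes: a chloro substitution in a maximal-response series

The source may hold more compounds than are shown below. What is called first, only, known or untested is meant among the compounds shown, and "the series" means these compounds.

Measured compounds and their maximal responses:
compound 1, `CC(C)CCn1ccc(N2CCC(c3ccccc3)CC2)c(C#N)c1=O`, 268%
compound 2, `CCCCn1ccc(N2CCC(c3ccccc3)CC2)c(C#N)c1=O`, 309%
compound 3, `N#Cc1c(N2CCC(c3ccccc3)CC2)ccn(CC2CC2)c1=O`, 309%

In a functional assay on CHO cells for positive allosteric modulation of metabotropic glutamate receptor 2 (Homo sapiens), with a stated time of 30 min (a higher number here means a larger maximal response, a lower number a smaller maximal response), compound 3 stands level with compound 2 (no change at the digits printed from compound 2 to compound 3 (within the scatter)), the two together giving the largest maximal responses measured so far, while compound 1 lies lower (a number 41 percentage points higher from compound 1 to compound 3 (beyond the scatter)). Compound 4 is `N#Cc1c(N2CCC(c3ccccc3Cl)CC2)ccn(CC2CC2)c1=O`; it differs from compound 3 in that (chloro in place of hydrogen on an aromatic carbon).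

All three measured steps, a number 41 percentage points higher from compound 1 to compound 2 (beyond the scatter), a number 41 percentage points higher from compound 1 to compound 3 (beyond the scatter) and no change at the digits printed from compound 2 to compound 3 (within the scatter), alter the group on the aromatic nitrogen. Going by the values given here, none changes the phenyl ring, so no measured step bears on this change. The estimate for compound 4 is therefore expected to sit close to compound 3, with a broad range: a number 9 percentage points lower from compound 3 to compound 4 (within the scatter). Compound 4 is estimated at 300%, within 230% to 370%.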

Compound 4, largest response reached (Emax), in percent of the reference or control that the assay uses: 259%
Beside the measured number, compound 4's estimate is 41 percentage points above it; measured number inside the range.
By their numbers in this assay, from the lowest: compounds 4 and 1 (each within the scatter of the next); then compounds 2 and 3 (each within the scatter of the next).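

Going by these compounds alone, the phenyl ring is the first place where a step can be read. In this assay, chloro in place of hydrogen on an aromatic carbon, ortho to a large group, gives a number 50 percentage points lower from compound 3 to compound 4 (beyond the scatter), so the maximal response is sensitive to substitution at this position as well as on the aromatic nitrogen. Nothing available accounts for this step.

As far as these compounds go, whether the step belongs to chloro itself or to any group at this place stays open. Fluoro, methyl or methoxy at the same carbon would separate these, and chloro at another carbon of the phenyl ring would show whether the position matters.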